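Bromo for Chloro: Carrying One Halogen Swap Across Two Cores

This account rests on a few compounds, and the source may have more. Where it says the series, first, only, none or still open, it means among the compounds named here.

Measured compounds:
Compound 1, `O=C(CCCCCCN1C(=O)/C(=N\O)c2cc(Cl)ccc21)NO`, gives 650 nM.
Compound 2, `O=C(CCCCCCN1C(=O)/C(=N\O)c2cc(Br)ccc21)NO`, gives 290 nM.
Compound 3, `CO/N=C1/C(=O)N(CCCCCCC(=O)NO)c2ccc(Cl)cc21`, gives 490 nM.

All three numbers come from a functional assay on SW-620 cells (Homo sapiens) for antiproliferative activity, read by sulforhodamine B assay, with a stated time of 48 h; a lower number here means a stronger inhibitor, a higher number a weaker inhibitor. Compound 1 and compound 2 share a core and differ in one place only:

bromo in place of chloro on an aromatic carbon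

That single exchange gave a 2.2-fold lower number from compound 1 to compound 2 (0.35 log units; beyond the scatter), a step that lies beyond the scatter of the assay, so the bromo compound can be counted as the stronger of the two.

Compound 3 is built on a different core; the difference between its core and that of compound 1 is not broken down here. In this assay compound 3 and compound 1 fall within the scatter of each other, so nothing can be said about their order.

Compound 4, `CO/N=C1/C(=O)N(CCCCCCC(=O)NO)c2ccc(Br)cc21`, has not yet been measured. It differs from compound 3 in exactly the way compound 2 differs from compound 1:

bromo in place of chloro on an aromatic carbon

Since the two "place" descriptions agree word for word, this is the same change on a second core. Within the data shown here, on that basis the step from compound 3 to compound 4 is expected to resemble the one from compound 1 to compound 2, which is the only instance of this change measured so far; the expectation is a 2.0-fold lower number from compound 3 to compound 4 (0.31 log units; beyond the scatter), and it rests on a 2.2-fold lower number from compound 1 to compound 2 (0.35 log units; beyond the scatter) together with the measured value of compound 3, 490 nM. Whether the second core responds the same way is not known, so the range is kept wide. Compound 4 is therefore estimated at 240 nM, with a likely span from 120 nM to 520 nM.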

Compound 4, half-maximal inhibitory concentration: 2320 nM
For compound 4 the middle estimate is 9.7-fold (0.99 log units) below the measured one, and the stated range ends below it.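

In this assay, the exchange of bromo for chloro on an aromatic carbon of the core of compound 3 gave a 4.7-fold higher number from compound 3 to compound 4 (0.68 log units; beyond the scatter), so on this core the bromo compound is the weaker of the pair, the reverse of what the same exchange did on the core of compound 1. The two instances of this one change therefore do not agree in direction, and the disagreement is larger than repeated measurement would explain: the same change on two cores in this assay, a 2.2-fold lower number (0.35 log units; beyond the scatter) from compound 1 to compound 2 and a 4.7-fold higher number (0.68 log units; beyond the scatter) from compound 3 to compound 4, 11-fold (1.03 log units) apart, beyond the scatter of two such steps. Among these compounds, this shows that, in this series, the effect of this exchange on one core cannot be carried over to the other, but it does not show what in the two cores sets the direction, nor which of the two steps is the more typical, since each core offers only a single pair.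

The compounds shown leave open whether a fluoro or an iodo group in the same place would follow the bromo compound on each core, or would split between the cores in the same way. They also leave open whether the reversal would persist with a longer chain ending in the same hydroxamic acid, or with a carboxylic acid at the end of the chain.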